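The compounds below may be only part of what the source reports. "The series", "measured", "known", "first", "only" and "open" are said of these compounds alone.

Of the compounds shown here, three with a shared core have so far been measured in an ADME assay on microsomes from liver (Homo sapiens) for metabolic stability; a higher number here means that the compound lasts longer, a lower number that the compound disappears faster. Compound 1 `CC(C)[C@H](C[C@H]1CCNC1=O)c1ccc(-c2ccc3cccc(F)c3c2)[nH]c1=O` gives 0.257 h while compound 2 `CC(C)C(c1ccc(-c2ccc3cccc(F)c3c2)[nH]c1=O)N1CCN/C1=N\C#N` gives 0.632 h and compound 3 `CCC(CC)(c1nnc[nH]1)c1ccc(-c2ccc3cccc(F)c3c2)[nH]c1=O` gives 1.19 h as its half-life. Compound 2 therefore stands within the usual scatter of compound 3, and beyond the scatter from compound 1, whose number is the lower of that pair.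

Compound 4 `CC(C)C(Cc1nnn[nH]1)c1ccc(-c2ccc3cccc(F)c3c2)[nH]c1=O` has not yet been measured. It differs from compound 2 in one place a group of 6 heavy atoms (2 carbon, 4 nitrogen; one five-membered aromatic ring with 4 hetero atoms) in place of a group of 8 heavy atoms (4 carbon, 4 nitrogen; one five-membered non-aromatic ring with 2 hetero atoms), on a saturated chain carbon bound to an aromatic carbon and a saturated chain carbon on a saturated chain carbon bound to an aromatic carbon and a saturated chain carbon. In plain terms, (1H-tetrazol-5-yl)methyl replaces a group built on a five-membered non-aromatic ring.

Among the measured compounds shown here, no two measured compounds differ in only one place, so no direct guide to this change exists. The expectation rests only on the span from compound 1 at 0.257 h to compound 3 at 1.19 h in this assay and leans slightly upward. The estimated step is a 1.4-fold higher number from compound 2 to compound 4 (0.15 log units; within the scatter) and is expected to stay within the scatter. The estimated half-life of compound 4 is 0.9 h (expected range 0.3 h to 2.5 h).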

Compound 4, half-life: > 3 h
Compound 4: only a limit was reported; the forecaster's own chance of this, stated with the estimate: 5%; at least 3.3-fold (0.52 log units) between middle value and limit.
By their numbers in this assay, from the lowest: compound 1; then compounds 2 and 3 (each within the scatter of the next). At a limit, above all of these: compound 4.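

In this assay, among the compounds shown here, replacing the group on a five-membered non-aromatic ring of compound 2 with (1H-tetrazol-5-yl)methyl gives the first step that can be read between compounds differing in one place: an at least 4.7-fold higher number from compound 2 to compound 4 (0.67 log units; beyond the scatter). For the compounds shown here, this shows that a change on this saturated chain carbon alone can move the half-life beyond the usual scatter, something the earlier compounds, which differ in more than one place, could not show. Compound 4 stands at a limit and not at a number, so the full size of the step stays unknown: the limit of > 3 h in this assay, at which 1 of the 4 values shown sits.

The compounds shown leave open whether the step belongs to the tetrazole ring itself or to the methyl link that carries it. A carboxylic acid in the same place, or a tetrazole without that methyl link, would help to separate the two.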